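The source may report more compounds than this note shows. Statements on the series, on what has been measured and on what is new or still open speak of the compounds shown alone.

Measured so far in an ADME assay on cells (Hepatocyte, Rattus norvegicus, strain Wistar) for pharmacokinetics, read by LC-MS, with a stated time of 90 min, tested at 1 uM; a higher number here means faster removal of the compound, a lower number slower removal:

- Compound 1 `COc1cc(C(=O)N2CC[C@@H](O)C(C)(C)C2)cc2nc(NCc3cccc(Cl)c3)oc12` gives 51.7 mL/min/kg
- Compound 2 `COc1cc(C(=O)N2CCC(O)C(C)C2)cc2nc(NCc3cncc(Cl)c3)oc12` gives 40 mL/min/kg
- Compound 3 `COc1cc(C(=O)N2CCC(O)C(C)C2)cn2nc(NCc3cccc(Cl)c3)nc12` gives 35 mL/min/kg

Compound 1 gives the highest of these three numbers, yet its gaps to compound 2 and compound 3 both fall within the usual scatter of repeated measurements. The three compounds therefore cannot be told apart in this assay with any confidence.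

The next compound to be measured is compound 4 `CCC1CC(O)C(C)CN1C(=O)c1cc(OC)c2oc(NCc3cccc(Cl)c3)nc2c1`. It keeps the core of compound 1 and changes only the ring attached through the amide: 2-ethyl-4-hydroxy-5-methylpiperidin-1-yl stands in place of 4-hydroxy-3,3-dimethylpiperidin-1-yl on a carbonyl carbon (2-ethyl-4-hydroxy-5-methylpiperidin-1-yl in place of 4-hydroxy-3,3-dimethylpiperidin-1-yl on a carbonyl carbon).

Going by the values given here, no two measured compounds differ in just one place, so the data offer no measured size for a change of this kind. With no such guide, the natural starting point is compound 1 at 51.7 mL/min/kg in this assay, and no shift beyond the scatter is expected in either direction. The estimated step of a 1.1-fold lower number from compound 1 to compound 4 (0.03 log units; within the scatter) is expected to stay within that scatter. Compound 4 is estimated at 48 mL/min/kg with an expected range from 30 mL/min/kg to 72 mL/min/kg once it has been measured.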

Compound 4, clearance: 61.7 mL/min/kg
For compound 4 the middle estimate is 1.3-fold (0.11 log units) below the measured one, within the range that was stated.
By their numbers in this assay, from the lowest: compounds 3, 2, 1 and 4 (each within the scatter of the next).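

At this place on the carbonyl carbon, this assay now gives its first direct reading of a single swap: 2-ethyl-4-hydroxy-5-methylpiperidin-1-yl in place of 4-hydroxy-3,3-dimethylpiperidin-1-yl amounts to a 1.2-fold higher number from compound 1 to compound 4 (0.08 log units; within the scatter). The ring can therefore be rebuilt in this one pair, with 10 heavy atoms in the entering group against 9 in the leaving one and the same count of hydrogen-bond donors and acceptors, without a difference that can be told from the scatter. Nothing in the data explains this result, and no measurement bears on why the two groups cannot be told apart.

This single step swaps the whole group at once, so the ethyl and methyl groups cannot be judged separately, and either one alone could have an effect that the other hides. On these data alone, compounds 1 and 4 both keep a hydroxy group on the ring, so it remains open whether an amine or a carboxylic acid there would give a number beyond the scatter.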